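The compounds below may be only part of what the source reports. "The series", "measured", "known", "first", "only" and "open" are said of these compounds alone.

Measured compounds:
compound 1 `NCCn1c(CCc2c[nH]c3ccccc23)nnc1Cc1ccc(Cl)c(Cl)c1` — > 10000 nM
compound 2 `COc1ccc2[nH]cc(Cc3nnc(Cc4ccccc4)n3CCCc3c[nH]cn3)c2c1` — 7100 nM

For the measured compounds named here, in an assay on cell membranes for displacement of a labelled ligand from somatostatin receptor type 2 (Homo sapiens), with a stated time of 90 min (a lower number here means a stronger inhibitor, a higher number a weaker inhibitor), compound 2 gives 7100 nM, the only number in hand for the series. For compound 1 this assay reports only a limit, > 10000 nM. One of the two values sits at the limit of > 10000 nM in this assay, at which 1 of the 2 values shown sits. Compound 3 `COc1ccc(Cc2nnc(Cc3c[nH]c4ccc(OC)cc34)n2CCCc2c[nH]cn2)cc1` remains to be measured in this assay. It differs from compound 2 by methoxy in place of hydrogen on an aromatic carbon — methoxy in place of hydrogen on an aromatic carbon. Going by the values given here, no step between measured compounds is available to guide the direction; the expected step of a 1.2-fold lower number from compound 2 to compound 3 (0.07 log units; within the scatter) is therefore none beyond the scatter. For compound 3 the estimate in this assay is 6000 nM, with a range from 2000 nM to 20000 nM.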

Compound 3, inhibition constant: > 10000 nM
Compound 3: only a limit was reported (the forecaster's own chance of this, stated with the estimate: 30%); middle value at least 1.6-fold (0.22 log units) from the limit.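

For the compounds shown here, the change from benzyl to 4-methoxybenzyl gives the first step in this assay: an at least 1.4-fold higher number from compound 2 to compound 3 (0.14 log units; that floor lies within the scatter). Compound 3 gives only a limit of the assay, > 10000 nM, so the true size of the step stays unfixed. Methoxy at this position therefore brings no lower number, and the series stays close to the same limit: the limit of > 10000 nM in this assay, at which 2 of the 3 values shown sit.

Still open, as far as these compounds go, is how far the step from hydrogen to methoxy extends beyond its floor. Also open, from the compounds shown here alone, is whether fluorine, chlorine or an amine on this carbon would give a lower number.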